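A Benzyl Swap on the Branching Carbon

A few compounds are considered here, and "the series" means these few. Any claim that something is new, unique, unknown or untested is made for them only; others in the source may bear on it.

compound 1 `CC1CCN(c2nc(C(F)(F)F)ccc2CNC(=O)C(c2ccc(NS(C)(=O)=O)c(F)c2)C2CCCC2)CC1`: 88.7 nM
compound 2 `CS(=O)(=O)Nc1ccc(C(C(=O)NCc2ccc(C(F)(F)F)nc2SC2CCCCC2)c2cccc(F)c2)cc1F`: 48.7 nM
compound 3 `CC1CCN(c2nc(C(F)(F)F)ccc2CNC(=O)C(Cc2ccccc2)c2ccc(NS(C)(=O)=O)c(F)c2)CC1`: 65.9 nM

Of the compounds shown here, three have been measured in an assay on CHO cells for antagonist activity at transient receptor potential cation channel subfamily V member 1 (Homo sapiens), read by FLIPR; a higher number here means a weaker inhibitor, a lower number a stronger inhibitor. Compound 2 shows the lowest of the three numbers, though its gaps to compound 3 and to compound 1 both lie within the scatter, so no order among them is established. Compound 4 `Cc1ccc(CC(C(=O)NCc2ccc(C(F)(F)F)nc2SC2CCCCC2)c2ccc(NS(C)(=O)=O)c(F)c2)cc1` is not yet measured. It differs from compound 2 in one place: 4-methylbenzyl in place of 3-fluorophenyl on a saturated chain carbon bound to an aromatic carbon and a carbonyl carbon. Among the compounds with values here, one measured step touches that same carbon, a 1.3-fold lower number from compound 1 to compound 3 (0.13 log units; within the scatter), and it stayed within the scatter while also bringing in a benzyl group. For compound 4 a similar outcome is expected: a 1.2-fold higher number from compound 2 to compound 4 (0.09 log units; within the scatter), no step beyond the scatter. Compound 4 is therefore estimated at 60 nM, within the range 20 nM to 180 nM.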

Compound 4, inhibition constant: 40.3 nM
Compound 4: middle estimate off by 1.5-fold (0.17 log units), on the high side, within the range that was stated.
By their numbers in this assay, from the lowest: compounds 4, 2, 3 and 1 (each within the scatter of the next, the first and the last beyond it).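

In this assay, 4-methylbenzyl in place of 3-fluorophenyl gives a 1.2-fold lower number from compound 2 to compound 4 (0.08 log units; within the scatter). This is the second step at this carbon to stay within the scatter, and it does so on a different core from the step between compound 1 and compound 3, so the position accepts an added methyl and a ring set one carbon further out. No available measurement explains this. The compounds shown leave open whether an amine or a carboxylic acid on that ring, or a longer chain before it, would move the number beyond the scatter.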